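This account rests on a few compounds, and the source may have more. Where it says the series, first, only, none or still open, it means among the compounds named here.

Two compounds of this series have so far been run in a functional assay on HCT-116 cells (Homo sapiens) for cytotoxicity, read by MTT assay, with a stated time of 48 h; on this read-out lower numbers stand for stronger inhibition and higher numbers for weaker inhibition. Compound 1 `Cc1ccc(C(=O)/C=C/c2ccc3c(c2)B(O)OC3)cc1` gives 10500 nM in this assay. Going by the values given here, compound 2 `O=C(/C=C/c1ccc2c(c1)B(O)OC2)c1ccc(OCc2ccccc2)cc1` gives 12100 nM in this assay, which is the higher of the two numbers, with compound 1 as its only and nearest neighbour. Among the compounds with values here, the single measured step, a 1.2-fold higher number from compound 1 to compound 2 (0.06 log units; within the scatter), shows that exchanging methyl for benzyloxy on the aromatic carbon left the read-out essentially unchanged.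

Compound 3 `O=C(/C=C/c1ccc2c(c1)B(O)OC2)c1ccc([N+](=O)[O-])cc1` has not yet been measured. It differs from compound 2 in one place: nitro in place of benzyloxy on an aromatic carbon. Within the data shown here, the only measured step that touches this position is the one from compound 1 to compound 2, and it stayed within the scatter. Among the measured compounds shown here, no measured compound carries a nitro at this site, so nothing in the data points to a shift in either direction beyond the scatter. Compound 3 is therefore expected to show a 1.2-fold lower number from compound 2 to compound 3 (0.08 log units; within the scatter). Compound 3 is estimated at 10000 nM in this assay, within a range from 4000 nM to 25000 nM.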

Compound 3, half-maximal inhibitory concentration: 9100 nM
For compound 3 the middle estimate is 1.1-fold (0.04 log units) above the measured one, within the range that was stated.
By their numbers in this assay, from the lowest: compounds 3, 1 and 2 (each within the scatter of the next).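

With nitro at this aromatic carbon, para to a large group, this assay gives a 1.3-fold lower number from compound 2 to compound 3 (0.12 log units; within the scatter) and also a 1.2-fold lower number from compound 1 to compound 3 (0.06 log units; within the scatter) for the exchange of methyl, so a third group now joins the other two within the scatter. The earlier pair had covered only methyl and benzyloxy, whereas this result shows that the read-out stays within the scatter even between benzyloxy, which carries a six-membered aromatic ring of carbon only, and nitro, which has no ring and brings a double bond outside aromatic rings. Nothing in the data at hand bears on why these three groups read alike.

As far as these compounds go, it remains open whether an amine, a carboxylic acid or a longer chain at this same aromatic carbon would also stay within the scatter, or whether one of them would move the number beyond it. The compounds shown all share one core and vary at this one place only, so they leave open how the read-out responds to any exchange elsewhere on the core of compound 1.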